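The source may report more compounds than this note shows. Statements on the series, on what has been measured and on what is new or still open speak of the compounds shown alone.

compound 1 `CCCCC[C@@H]1CC=CC(=O)O1` — 20.2 ug/mL
compound 2 `CCC1CC=CC(=O)O1` — "not determined" (no result reported)

In a functional assay on K562 cells (Homo sapiens) for cytotoxicity, read by MTT assay, with a stated time of 72 h (a lower number here means a stronger inhibitor, a higher number a weaker inhibitor), compound 1 gives 20.2 ug/mL. In this assay, among the measured compounds shown here, compound 2 gives "not determined" (no result reported), so it stands on no number here, and no step can be drawn from it. Compound 3 `C=CCOCC1CC=CC(=O)O1` differs from compound 2 by allyloxy in place of methyl on a saturated chain carbon bound to a saturated ring carbon. For the measured compounds named here, no step between measured compounds is available to size this change, so for this assay no direction is expected with confidence, and any shift from compound 2 to compound 3 is taken as not beyond the scatter. Compound 3 is expected to give 35 ug/mL in this assay, within 10 ug/mL to 120 ug/mL.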

Compound 3, half-maximal inhibitory concentration: 50 ug/mL
For compound 3 the middle estimate is 1.4-fold (0.15 log units) below the measured one; the range from low to high includes it.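

No new step can be read between compound 2 and compound 3 in this assay. The compounds shown leave open what allyloxy in place of methyl does to the value. Nothing shown bears on a cause for this result.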